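The source may hold more compounds than are shown below. What is called first, only, known or untested is meant among the compounds shown, and "the series" means these compounds.

Measured compounds in a functional assay on HepG2 cells (Homo sapiens) for cytotoxicity, read by MTT assay, with a stated time of 48 h; on this read-out higher numbers stand for weaker inhibition and lower numbers for stronger inhibition:

compound 1 `Cc1nnc(SCC(=O)c2ccc(Cl)cc2)n1N1C(=O)c2ccccc2C1=O`: > 200000 nM, a limit of the assay.
compound 2 `Cc1ccc(C(=O)CSc2nnc(C)n2N2C(=O)c3ccccc3C2=O)cc1`: > 200000 nM, a limit of the assay.
compound 3 `Cc1nnc(SCC(=O)c2ccccc2)n1N1C(=O)c2ccccc2C1=O`: > 200000 nM, a limit of the assay.

Compound 1 stands only at a limit in this assay, and the same holds for compound 2 and compound 3, as the limit of > 200000 nM in this assay, at which 3 of the 3 values shown sit, records. The steps a step that the two limits leave unreadable from compound 1 to compound 2, a step that the two limits leave unreadable from compound 1 to compound 3 and a step that the two limits leave unreadable from compound 2 to compound 3 are therefore unreadable in size; all three changes sit on an aromatic carbon.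

Compound 4 `Cc1nnc(SCc2ccccc2Cl)n1N1C(=O)c2ccccc2C1=O` differs from compound 1 by 2-chlorophenyl in place of (4-chlorophenyl)carbonyl on a saturated chain carbon bound to a sulfur. Among the measured compounds shown here, none of the measured steps touches this part of the structure, so no step bears directly on it. With every value shown sitting at a limit, no change beyond the scatter is expected in this assay: the step of a number no higher from compound 1 to compound 4 (the limit leaves the size open) is estimated as none. Compound 4 is therefore expected to give 200000 nM, with a range from 50000 nM to 500000 nM.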

Compound 4, half-maximal inhibitory concentration: > 200000 nM
Compound 4: a limit, no number (the forecaster's own chance of this, stated with the estimate: 80%); the middle value sits exactly at the limit.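

In this assay, among the compounds shown here, compound 4 stands only at a limit, so no step from it to compound 1, compound 2 or compound 3 can be read: the limit of > 200000 nM in this assay, at which 4 of the 4 values shown sit. The compounds shown leave open what number any of these four would give in this assay on this read-out.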